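The source may hold more compounds than are shown below. What is called first, only, known or untested is meant among the compounds shown, and "the series" means these compounds.

Compound 1, `CN(C)C12CCN(CCCN3CCCCC3)C(C(c3ccccc3)C1)C(c1ccccc1)C2`, gives 58400 nM in an ADME assay on L6 cells (Rattus norvegicus) for cytotoxicity; on this read-out higher numbers stand for weaker inhibition and lower numbers for stronger inhibition. Compound 2, `CN(C)C12CCN(CCN3CCCC3)C(C(c3ccccc3)C1)C(c1ccccc1)C2`, gives 80400 nM. Compound 3, `CN1CCN(CC(=O)N2CCC3(N4CCCC4)CC(c4ccccc4)C2C(c2ccccc2)C3)CC1`, gives 69100 nM.

On these three numbers compound 3 stands second highest; its nearest neighbour is compound 2 and its furthest compound 1, both within the scatter, so the three cannot be told apart on this read-out. Compound 4, `CN1CCN(CCC(=O)N2CCC3(N4CCCC4)CC(c4ccccc4)C2C(c2ccccc2)C3)CC1`, is not yet measured. It differs from compound 3 in one place: (4-methylpiperazin-1-yl)methyl in place of 4-methylpiperazin-1-yl on a saturated chain carbon bound to a carbonyl carbon. For the measured compounds named here, the only measured step, a 1.4-fold higher number from compound 1 to compound 2 (0.14 log units; within the scatter), alters a chain on a saturated chain carbon two bonds along the chain from an amine nitrogen in a ring, not a chain bound to a carbonyl carbon, and it stayed within the scatter. Nothing here points to a shift beyond the scatter, so compound 4 is expected to give a number close to compound 3, with a 1.0-fold lower number from compound 3 to compound 4 (0.00 log units; within the scatter). The estimate for compound 4 is 69000 nM, between 35000 nM and 140000 nM.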

Compound 4, half-maximal inhibitory concentration: 75400 nM
Compound 4: the middle estimate sits 1.1-fold (0.04 log units) below what was measured, within the range that was stated.
By their numbers in this assay, from the lowest: compounds 1, 3, 4 and 2 (each within the scatter of the next).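

Swapping 4-methylpiperazin-1-yl for (4-methylpiperazin-1-yl)methyl on a saturated chain carbon bound to a carbonyl carbon gives a 1.1-fold higher number from compound 3 to compound 4 (0.04 log units; within the scatter) in this assay, so this is a change that stays within the scatter. It is the first step shown at this position, and it shows that this position tolerates the lengthened link without a readable shift on this read-out. No measurement at hand offers an explanation for this result. Still open, from the compounds shown here alone, is whether a longer chain, such as 3-(4-methylpiperazin-1-yl)propyl, would also leave the number within the scatter. A different end group at this position, such as a morpholine ring or a carboxylic acid, is equally untested among the compounds shown.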